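The source may report more compounds than this note shows. Statements on the series, on what has been measured and on what is new or still open speak of the compounds shown alone.

Working notes on the series. Compound 1 `CCCC(C(C)C)n1ccc2cc(/C(C)=C/C(=O)Nc3ccccc3OCCCC(=O)O)ccc21` gives 7.2 nM in an assay on Prostate gland for inhibition of steroid 5-alpha-reductase (Rattus norvegicus); a higher number here means a weaker inhibitor, a lower number a stronger inhibitor. Among the measured compounds shown here, compound 2 `CCCCc1ccc(Cn2ccc3cc(/C(C)=C/C(=O)Nc4ccccc4OCCCC(=O)O)ccc32)cc1` gives 100 nM in this assay and stands as the highest of the two numbers measured so far; its nearest neighbour is compound 1, and the step of a 14-fold higher number from compound 1 to compound 2 (1.14 log units; beyond the scatter) is the only measured step in the set. Compound 3 `C/C(=C\C(=O)Nc1ccccc1OCCCC(=O)O)c1ccc2c(ccn2C(C)c2ccccc2)c1` has not been measured. Its change from compound 2 is 1-phenylethyl in place of 4-butylbenzyl on an aromatic nitrogen. For the measured compounds named here, the one measured step bears on this only in part: it shows that the group on the aromatic nitrogen shifts the number strongly, with the 1-isopropylbutyl of compound 1 giving the lower number and the 4-butylbenzyl of compound 2 the higher. The 1-phenylethyl of compound 3 keeps a six-membered aromatic ring of carbon only, as in compound 2, yet is the smaller group and lies nearer in shape to the 1-isopropylbutyl of compound 1. A step downward is therefore expected: a 2.5-fold lower number from compound 2 to compound 3 (0.40 log units; beyond the scatter). This expected step is taken to fall short of undoing the measured step of a 14-fold higher number from compound 1 to compound 2 (1.14 log units; beyond the scatter). Compound 3 is estimated at 40 nM in this assay, with a range from 10 nM to 200 nM.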

Compound 3, half-maximal inhibitory concentration: 19 nM
Compound 3: middle estimate off by 2.1-fold (0.32 log units), on the high side; the measured number falls inside the stated range.
By their numbers in this assay, from the lowest: compound 1; then compound 3; then compound 2.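

Within this assay, the aromatic nitrogen of the five-membered ring now carries three different groups, and the six-membered aromatic ring of carbon only does not by itself set the number: exchanging 4-butylbenzyl for 1-phenylethyl keeps that ring, yet gives a 5.3-fold lower number from compound 2 to compound 3 (0.72 log units; beyond the scatter). That ring is still present in a compound close to the non-aromatic 1-isopropylbutyl comparator, although a gap beyond the scatter remains, with a 2.6-fold higher number from compound 1 to compound 3 (0.42 log units; beyond the scatter), so the order across the three groups is 1-isopropylbutyl, then 1-phenylethyl, then 4-butylbenzyl. No measurement at hand explains either step.

The compounds shown leave open whether the drop from compound 2 to compound 3 goes with the loss of the butyl chain or with the change from a benzyl to a 1-phenylethyl attachment, a distinction that a plain benzyl or a 1-phenylbutyl on the aromatic nitrogen would address. They also leave open how a saturated ring group such as 1-cyclohexylethyl would compare with the 1-phenylethyl of compound 3 on the same core.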